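Pyridin-2-yl for 2,5-dimethoxyphenyl on the sulfonyl sulfur

The source may hold more compounds than are shown below. What is called first, only, known or untested is meant among the compounds shown, and "the series" means these compounds.

Three compounds of the series carry a number in a functional assay (trachea) for antagonist activity, with Cavia porcellus as the target; a lower number here means a less potent compound, a higher number a more potent compound, by a factor of ten per unit of this negative logarithm. Compound 1 `COc1cc(C(=O)NS(=O)(=O)c2ccccc2C)ccc1Cn1ncc2ccc(NC(=O)OC3CCCC3)cc21` gives 10.2, compound 2 `COc1ccc(OC)c(S(=O)(=O)NC(=O)c2ccc(Cn3ccc4ccc(NC(=O)CC5CCCC5)cc43)c(OC)c2)c1` gives 9.1, and compound 3 `CCCCC(CC)C(=O)Nc1ccc2ccn(Cc3ccc(C(=O)NS(=O)(=O)c4ccc(F)cc4)cc3OC)c2c1` gives 7.7. Compound 2 stands second of the three: compound 1 lies higher by more than the scatter, compound 3 lower by more than the scatter. Among the compounds with values here, compounds 1 and 3 each differ from compound 2 in more than one place, so no single-point step is available. Compound 4 `COc1cc(C(=O)NS(=O)(=O)c2ccccn2)ccc1Cn1ccc2ccc(NC(=O)CC3CCCC3)cc21` differs from compound 2 in one place: pyridin-2-yl in place of 2,5-dimethoxyphenyl on a sulfonyl sulfur. Without a clean precedent, a modest loss is expected, a number 0.40 log units lower from compound 2 to compound 4 (beyond the scatter). Compound 4 is estimated at 8.7, with a range of 8 to 9.4 in this assay.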

Compound 4, negative logarithm of the antagonist equilibrium constant: 8.9
The estimate for compound 4 lay 0.20 log units below the measured number, within the range that was stated.
By their numbers in this assay, from the lowest: compound 3; then compounds 4 and 2 (each within the scatter of the next); then compound 1.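

Within the data shown here, on a sulfonyl sulfur, pyridin-2-yl in place of 2,5-dimethoxyphenyl gives in this assay a number 0.20 log units lower from compound 2 to compound 4 (within the scatter) as the first single-point step. At this position, a group of 6 heavy atoms with a ring nitrogen thus reads the same as one of 10 heavy atoms carrying the two methoxy groups. No supporting measurement bears on this result. Open, from the compounds shown here alone, is whether a plain phenyl, a pyridin-3-yl or a carboxylic acid on the pyridin-2-yl ring would read alike there. Also open, going by these compounds, is whether the step holds on the cores of compound 1 and compound 3.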